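The compounds below may be only part of what the source reports. "The series", "measured", "known", "first", "only" and "open" are said of these compounds alone.

Measured in a functional assay on the whole organism (Tail, strain ICR) with Mus musculus as the target, in the tail flick test, with a stated time of 60 min, at a dose of 25 umol/kg by the oral route; a lower number here means a weaker effect, a higher number a stronger effect of the compound at the dose given:
compound 1 `O=C(CN(c1ncnc2c1ncn2C1CCCCO1)C1CC1)N[C@@H](CCC(=O)OCc1ccccc1)C(=O)OCc1ccccc1`: 34.7%
compound 2 `CSCC[C@H](NC(=O)CN(c1nc(Cl)nc2[nH]cnc12)C1CC1)C(=O)OCc1ccccc1`: 30.8%
compound 3 `O=C(O)C[C@H](NC(=O)CN(c1nc(Cl)nc2[nH]cnc12)C1CC1)C(=O)O`: 38.9%

The three numbers lie close together. Compound 1 sits among them, with compound 2 and compound 3 each within the usual scatter of it, so no ordering of the three can be read from these values. Compound 4 `CC(C)[C@H](NC(=O)CN(c1ncnc2c1ncn2C1CCCCO1)C1CC1)C(=O)OCc1ccccc1` is not yet measured. It differs from compound 1 in one place: isopropyl in place of 2-(benzyloxycarbonyl)ethyl on a saturated chain carbon bound to an amide-type nitrogen and a carbonyl carbon. Among the measured compounds shown here, no pair of measured compounds differs in a single place, so there is no measured step to lean on. No change beyond the scatter is expected, because compound 2 gives 30.8% and compound 3 gives 38.9% while compound 1 gives 34.7% despite quite different substituents. A step of a number 2.7 percentage points lower from compound 1 to compound 4 (within the scatter) is estimated, leaning slightly downward if anything. Compound 4 is expected to give about 32%, in the range 17% to 47%.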

Compound 4, a percentage reported as activity, at one dose (the size of the read-out at that dose, not a potency): 34.9%
Estimate against measurement, compound 4: 2.9 percentage points below; the measured number falls inside the stated range.
By their numbers in this assay, from the lowest: compounds 2, 1, 4 and 3 (each within the scatter of the next).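

In this assay, among the compounds shown here, the step at this position is a number 0.2 percentage points higher from compound 1 to compound 4 (within the scatter), the first comparison that isolates a single change. On a saturated chain carbon bound to an amide-type nitrogen and a carbonyl carbon, 2-(benzyloxycarbonyl)ethyl with its six-membered aromatic ring can thus give way to the much smaller isopropyl without a change beyond the scatter at this dose. No measurement at hand accounts for this result.

On these data alone, whether a primary amine or an unbranched hexyl chain on this carbon would also stay within the scatter remains open. The single dose also leaves potency unresolved.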